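Adding a Carboxy Group to a 5-Lipoxygenase Inhibitor

A few compounds are considered here, and "the series" means these few. Any claim that something is new, unique, unknown or untested is made for them only; others in the source may bear on it.

Measured compounds:
compound 1 `CCCc1cc2c(cc1O)C(C)(C)C(CCc1ccc(SC)cc1)O2` — 92 nM
compound 2 `C=CCc1cc2c(cc1O)CC(CCc1ccccc1)O2` — 17 nM
compound 3 `Oc1cc2c(cc1CCCOc1ccccc1)OC(CCc1ccccc1)C2` — 23 nM

In an assay for inhibition of Polyunsaturated fatty acid 5-lipoxygenase (Rattus norvegicus) (on this read-out lower numbers stand for stronger inhibition and higher numbers for weaker inhibition), compound 3 gives 23 nM, the second highest of the three numbers. Its closest neighbour is compound 2, with 17 nM; the step of a 1.4-fold higher number from compound 2 to compound 3 (0.13 log units; within the scatter) is within the scatter, so the two cannot be told apart. Compound 1, with 92 nM, lies furthest away, and that gap is beyond the scatter.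

Compound 4 `O=C(O)c1ccc(OCCCc2cc3c(cc2O)CC(CCc2ccccc2)O3)cc1` is not yet measured. It differs from compound 3 by carboxy in place of hydrogen on an aromatic carbon. For the measured compounds named here, none of the measured steps changes the same part of the molecule, so no direct precedent exists. Going by the values given here, the only measured step, a 1.4-fold higher number from compound 2 to compound 3 (0.13 log units; within the scatter), shows that a larger change at the chain on the shared core left the number within the scatter. On that slender basis a modest step is expected, a 1.7-fold higher number from compound 3 to compound 4 (0.24 log units; within the scatter), with a wide margin either way. Compound 4 is therefore estimated at 40 nM, in a range from 10 nM to 200 nM.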

Compound 4, half-maximal inhibitory concentration: 44 nM
Compound 4: middle estimate off by 1.1-fold (0.04 log units), on the low side; low and high end bracket the measured number.
By their numbers in this assay, from the lowest: compounds 2, 3 and 4 (each within the scatter of the next, the first and the last beyond it); then compound 1.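

Putting carboxy in place of hydrogen on an aromatic carbon, para to a large group, turns phenoxy into 4-carboxyphenoxy and gives a 1.9-fold higher number from compound 3 to compound 4 (0.28 log units; within the scatter), so in this assay the two compounds cannot be told apart. The earlier step changed the chain on the shared core as a whole, whereas this one shows that the far aromatic ring of that chain can take on 3 more heavy atoms, including a hydrogen-bond donor, with no change beyond the scatter. No measurement here explains why the number holds so steady.

From the compounds shown here alone, whether a methyl ester or an amine at the same place would also stay within the scatter remains open. So does the effect of moving the carboxy group to another carbon of that ring, or of a longer chain leading to it.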